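This account rests on a few compounds, and the source may have more. Where it says the series, first, only, none or still open, it means among the compounds named here.

Compound 1 `O=C(CCC1C(=O)N(c2ccc(Cl)cc2)C(=O)N1Cc1ccc(Br)cc1)Nc1ccc(C(=O)NO)cc1`: 6700 nM
Compound 2 `Cc1ccc(CN2C(=O)N(c3ccc(Cl)cc3)C(=O)C2CCC(=O)Nc2ccc(C(=O)NO)cc2)cc1`: > 100000 nM, a limit of the assay rather than a number

In an assay on isolated protein for inhibition of histone deacetylase 8 (Homo sapiens), read by fluorescence, with stated times of 5 min and 60 min (a higher number here means a weaker inhibitor, a lower number a stronger inhibitor), compound 2 sits at the assay limit (the limit of > 100000 nM in this assay, at which 1 of the 2 values shown sits), so only a boundary is known for it. Compound 3 `O=C(CCC1C(=O)N(c2ccc(Cl)cc2)C(=O)N1Cc1ccccc1)Nc1ccc(C(=O)NO)cc1` differs from compound 2 by hydrogen in place of methyl on an aromatic carbon. Within the data shown here, the one measured step, an at least 14-fold higher number from compound 1 to compound 2 (1.17 log units; beyond the scatter), shows that a change at this aromatic carbon can move this assay strongly, but it compares bromo with methyl, not methyl with hydrogen, so its direction does not transfer directly. A moderate gain is expected for compound 3, as an at least 2.0-fold lower number from compound 2 to compound 3 (0.30 log units; that floor lies within the scatter). Compound 3 is therefore estimated at 50000 nM, with a range from 10000 nM to 200000 nM.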

Compound 3, half-maximal inhibitory concentration: 3600 nM
The estimate for compound 3 lay 14-fold (1.14 log units) above the measured number; the whole stated range lies above it.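

In this assay, taking the methyl off the 4-methylbenzyl group brings back measurable inhibition (an at least 27-fold lower number from compound 2 to compound 3 (1.44 log units; beyond the scatter)), so the large loss seen earlier goes with methyl itself and not simply with the absence of bromo. Hydrogen and bromo on this aromatic carbon cannot be told apart (a 1.9-fold lower number from compound 1 to compound 3 (0.27 log units; within the scatter)). Compound 2 stands only as a limit of the assay: the limit of > 100000 nM in this assay, at which 1 of the 3 values shown sits.

On these data alone, whether a fluoro, methoxy or amine group here would track hydrogen and bromo or methyl stays open. So does the true size of the loss with compound 2.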